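Adding a propyl group to compound 2

The source may report more compounds than this note shows. Statements on the series, on what has been measured and on what is new or still open speak of the compounds shown alone.

Measured in a functional assay on A549 cells (Homo sapiens) for antiproliferative activity, read by CCK-8 assay, with a stated time of 72 h (a higher number here means a weaker inhibitor, a lower number a stronger inhibitor), as follows
Compound 1 `O=C(/C=C/c1ccc(CN2CCc3ccccc32)cc1)NO` gives 5480 nM
Compound 2 `Nc1ccccc1NC(=O)c1ccc(COc2ccccc2)cc1` gives 6760 nM
Compound 3 `Nc1cnccc1NC(=O)/C=C/c1ccc(COc2ccccc2)cc1` gives > 32000 nM (a limit)

Compound 1 (5480 nM) and compound 2 (6760 nM) lie within the usual scatter of each other, so this assay does not separate them. For compound 3 this assay gives only a limit (> 32000 nM) and no number.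

Compound 4 `CCCc1ccc(OCc2ccc(C(=O)Nc3ccccc3N)cc2)cc1` differs from compound 2 in one place (propyl in place of hydrogen on an aromatic carbon), para to a large group. The phenyl thus becomes 4-propylphenyl. Within the data shown here, no measured pair here differs in only one place, so the data do not show what this change does. The closest guide is compound 2 (6760 nM) and the expectation stays near it, with no shift beyond the scatter in either direction. The estimated change is a 1.4-fold lower number from compound 2 to compound 4 (0.13 log units; within the scatter) and this remains an expectation. In this assay the estimate for compound 4 is 5000 nM within an expected range of 1500 nM to 16000 nM for now.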

Compound 4, half-maximal inhibitory concentration: 5210 nM
Beside the measured number, compound 4's estimate is 1.0-fold (0.02 log units) below it; low and high end bracket the measured number.
By their numbers in this assay, from the lowest: compounds 4, 1 and 2 (each within the scatter of the next). At a limit, above all of these: compound 3.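

Propyl in place of hydrogen gives a 1.3-fold lower number from compound 2 to compound 4 (0.11 log units; within the scatter) in this assay and this is the first step here that changes only one place, so its effect can be read directly. It shows that phenyl and 4-propylphenyl are not separated by this assay: the propyl can stand on this aromatic carbon, para to a large group, with no shift beyond the scatter. Nothing shown here gives a reason for this outcome.

From the compounds shown here alone, whether a longer chain such as hexyl, an amine or a carboxylic acid at this place would shift the number beyond the scatter stays open. Also open, going by these compounds, is whether propyl would behave alike on the core of compound 3, which gives > 32000 nM as a limit and not a number.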